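The source may hold more compounds than are shown below. What is called first, only, known or untested is meant among the compounds shown, and "the series" means these compounds.

Of the compounds shown here, two that share one core have been measured in an assay for binding affinity to adenosine receptor A1 (Rattus norvegicus), read by radioligand binding; on this read-out lower numbers stand for stronger inhibition and higher numbers for weaker inhibition. Compound 1 `CCCn1c(=O)c2nc(-c3ccc(S(=O)(=O)NCCCC(=O)OCC)cc3)[nH]c2n(CCC)c1=O` gives 18.5 nM in this assay. Compound 2 `CCn1c(=O)c2nc(-c3ccc(S(=O)(=O)N4CCSCC4)cc3)[nH]c2n(CC)c1=O` gives 646 nM in this assay, the higher of the two numbers; its only partner, compound 1, sits at a lower number by a gap beyond the usual scatter. For the measured compounds named here, compound 2 differs from compound 1 in more than one place, so no single-change step connects them, and the two values only show where each compound stands.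

Compound 3 `CCn1c(=O)c2nc(-c3ccc(S(=O)(=O)O)cc3)[nH]c2n(CC)c1=O` has not yet been measured. It differs from compound 2 in one place: hydroxy in place of thiomorpholin-4-yl on a sulfonyl sulfur. Going by the values given here, no measured pair isolates this exchange, so any expectation about its effect rests on judgement rather than on a comparable example. For compound 3 in this assay a number near, or somewhat above, that of compound 2 is expected, and the step of a 2.3-fold higher number from compound 2 to compound 3 (0.37 log units; beyond the scatter) is estimated to be modest and upward, possibly within the scatter. The estimate for compound 3 is 1500 nM, with a range from 400 nM to 6000 nM.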

Compound 3, half-maximal inhibitory concentration: 5540 nM
For compound 3 the middle estimate is 3.7-fold (0.57 log units) below the measured one, and the stated range covers the measured number.
By their numbers in this assay, from the lowest: compound 1; then compound 2; then compound 3.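

In this assay, for the compounds shown here, putting hydroxy in place of thiomorpholin-4-yl on the sulfonyl sulfur gives an 8.6-fold higher number from compound 2 to compound 3 (0.93 log units; beyond the scatter), and this is the first step here in which only one place changes. It shows that the group on this sulfur affects the result when everything else stays the same, and that the sulfo compound binds more weakly than the one carrying the six-membered ring. Going by these compounds alone, the single exchange removes a ring of six heavy atoms and brings in one oxygen with its hydrogen-bond donor, and no measurement at hand explains why the number rises.

These compounds cannot separate the loss of the ring from the arrival of hydroxy, a question that a small amine such as dimethylamino or a ring such as morpholin-4-yl on the same sulfur could help to settle. On these data alone, it also remains open whether the same exchange would produce a step of similar size on the core of compound 1 , which differs from compound 2 in more than one place.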